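The compounds below may be only part of what the source reports. "The series", "measured", "known", "first", "only" and "open" are said of these compounds alone.

The measured compounds and their numbers in an ADME assay (liver) for metabolic stability, with Liver microsome (Rattus norvegicus) as the target, using microsomes; on this read-out higher numbers stand for fast clearance and lower numbers for slow clearance:

Compound 1 `C[C@H](c1ccc(F)cc1)N(Cc1cccc(C(=O)O)c1)C(=O)c1cc2ccccn2n1`, compound 1 gives 325 uL/min.
Compound 2 `C[C@H](c1ccc(F)cc1)N(Cc1cccc(C(=O)O)c1)C(=O)c1cn2ccccc2n1`, compound 2 gives 113 uL/min.
Compound 3 `C[C@H](c1ccc(F)cc1)N(Cc1cccc(C(=O)O)c1)C(=O)c1cc2ccccc2cn1`, compound 3 gives 166 uL/min.

Among these three, compound 1 has the highest number. Its nearest neighbour is compound 3, separated by a 2.0-fold lower number from compound 1 to compound 3 (0.29 log units; within the scatter). Compound 2 is further off, at a 2.9-fold lower number from compound 1 to compound 2 (0.46 log units; beyond the scatter). Between compound 2 and compound 3 the gap is a 1.5-fold higher number from compound 2 to compound 3 (0.17 log units; within the scatter).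

Compound 4 `C[C@H](c1ccc(F)cc1F)N(Cc1cccc(C(=O)O)c1)C(=O)c1cc2ccccn2n1` has not yet been measured in this assay. It differs from compound 1 in a single place: fluoro in place of hydrogen on an aromatic carbon. All three measured steps, from compound 1 to compound 2, from compound 1 to compound 3 and from compound 2 to compound 3, concern the group on the carbonyl carbon and leave the 4-fluorophenyl ring untouched. None of them therefore bears on the change from compound 1 to compound 4. Two of the three steps stayed within the scatter, and the one that went beyond it was modest. With nothing measured on this ring, the expected step for compound 4 is a 1.2-fold lower number from compound 1 to compound 4 (0.06 log units; within the scatter), that is, no step beyond the scatter, in either direction. The value expected for compound 4 in this assay is 280 uL/min, with a range from 140 uL/min to 560 uL/min.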

Compound 4, intrinsic clearance in a liver preparation (reported as CLH), per the amount of preparation that the assay uses: 85 uL/min
The estimate for compound 4 lay 3.3-fold (0.52 log units) above the measured number; the whole stated range lies above it.
By their numbers in this assay, from the lowest: compounds 4, 2, 3 and 1 (each within the scatter of the next, the first and the last beyond it).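

In this assay, among the compounds shown here, the aromatic carbon ortho to a large group on the 4-fluorophenyl ring proved sensitive to substitution: the change to 2,4-difluorophenyl gives a 3.8-fold lower number from compound 1 to compound 4 (0.58 log units; beyond the scatter) and is the first step measured on this ring. Adding one fluoro, a single heavy atom, thus produces a step that counts as modest and lies beyond the scatter, the same description as the one printed for exchanging the whole group on the carbonyl carbon, a 2.9-fold lower number from compound 1 to compound 2 (0.46 log units; beyond the scatter), so the 1-(4-fluorophenyl)ethyl part of the molecule also bears on this read-out, and not only the group on the carbonyl carbon. No measurement at hand accounts for the size or direction of this step.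

From the compounds shown here alone, whether chloro or methyl on the same aromatic carbon would give a step of similar size remains open, and so does the outcome of a fluoro elsewhere on the ring. Going by these compounds, it is also open whether the change to 2,4-difluorophenyl would give a comparable step when made on compound 2 or compound 3, which carry different groups on the carbonyl carbon.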